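Aryl group variation on the ring nitrogen of the core

This account rests on a few compounds, and the source may have more. Where it says the series, first, only, none or still open, it means among the compounds named here.

Working notes on the series. The shared core is shown by compound 1 `O=C(Nc1ccc(Oc2ccnc3[nH]ccc23)cc1)c1cc2cccnc2n(-c2ccc(F)cc2)c1=O`. In a functional assay on U-87MG ATCC cells for antiproliferative activity against U-87 MG (Homo sapiens), read by MTT assay, with a stated time of 72 h (on this read-out higher numbers stand for weaker inhibition and lower numbers for stronger inhibition), compound 1 gives 1360 nM. Compound 2 `O=C(Nc1ccc(Oc2ccnc3[nH]ccc23)cc1)c1cc2cccnc2n(-c2ccc(Br)cc2F)c1=O` differs from compound 1 only in the group carried on the aromatic nitrogen; in this assay compound 2 is recorded as "not determined" (no result reported), so compound 2 stands without a number of its own, and the only measured reference in the series remains compound 1. Compound 3 `O=C(Nc1ccc(Oc2ccnc3[nH]ccc23)cc1)c1cc2cccnc2n(-c2ccc(C(F)(F)F)cc2Cl)c1=O` has not yet been measured. It differs from compound 2 in one place: 2-chloro-4-(trifluoromethyl)phenyl in place of 4-bromo-2-fluorophenyl on an aromatic nitrogen. Among the measured compounds shown here, no measured step of this kind exists, so the size of the step from compound 2 to compound 3 in this assay cannot be read from the data; the expectation is a modest change in either direction, not clearly beyond the scatter, with the value of compound 1 as the only anchor. On that basis compound 3 is expected to give about 1000 nM in this assay, within a range from 200 nM to 5000 nM.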

Compound 3, half-maximal inhibitory concentration: 6030 nM
The estimate for compound 3 lay 6.0-fold (0.78 log units) below the measured number; the whole stated range lies below it.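

In this assay, among the compounds shown here, the exchange of 4-fluorophenyl for 2-chloro-4-(trifluoromethyl)phenyl on the aromatic nitrogen gives a 4.4-fold higher number from compound 1 to compound 3 (0.65 log units; beyond the scatter), and this is the first readable step. It shows that activity at this position depends on the aryl group carried on the nitrogen, and that this particular exchange moves the read-out towards weaker inhibition, although the finding rests on a single pair of compounds. Nothing at hand gives a measured reason for the size or direction of this step.

The step from compound 2 to compound 3 cannot be read, as compound 2 has no number, and compound 3 differs from compound 1 in both the chlorine and the trifluoromethyl group, so the contribution of each remains unseparated. Also open, on these data alone, is how the read-out would respond to an unsubstituted phenyl, a saturated cyclohexyl group, or a phenyl ring bearing an amine or a carboxylic acid on the same nitrogen.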